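A Methyl for Chloro Swap and Liver Cell Tolerance

The source may hold more compounds than are shown below. What is called first, only, known or untested is meant among the compounds shown, and "the series" means these compounds.

Three amides built on a shared core were examined in an ADME assay on HepG2 cells (Homo sapiens) for cytotoxicity, with a stated time of 72 h; a higher number here means that more compound is needed for the effect, a lower number that less compound is needed. Compound 1 `O=C(Nc1cc(-c2nc3ccccc3s2)ccc1Cl)c1cc([N+](=O)[O-])ccc1Cl` reached only a limit there: in this assay compound 1 gives > 25000 nM, which is a limit of the assay rather than a number. Compound 2 `O=C(Nc1cccc(-c2nc3ccccc3[nH]2)c1)c1cc([N+](=O)[O-])ccc1Cl` also stopped at a limit, giving > 27000 nM in this assay. Compound 3 `O=C(Nc1ccc(Cl)c(C(F)(F)F)c1)c1cc([N+](=O)[O-])ccc1Cl` likewise sits at a limit, with > 27000 nM in this assay. Compound 1 thus stands at the limit of > 25000 nM in this assay, at which 1 of the 3 values shown sits. The other two compounds stand at the limit of > 27000 nM in this assay, at which 2 of the 3 values shown sit. None of the three values separates itself from the others, so no order among them can be drawn.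

Compound 4 `Cc1ccc(-c2nc3ccccc3s2)cc1NC(=O)c1cc([N+](=O)[O-])ccc1Cl` has not yet been measured. It differs from compound 1 by methyl in place of chloro on an aromatic carbon. For the measured compounds named here, no step between measured compounds is available that would link such a change to a shift in cytotoxicity, and the three measured values give no sign of any movement beyond the scatter. The expected step that the limit leaves unreadable from compound 1 to compound 4 is none beyond the scatter. Compound 4 is therefore estimated at 30000 nM, with a range from 15000 nM to 60000 nM, and is most likely to be reported once more as a limit.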

Compound 4, half-maximal effective concentration: > 14000 nM
Compound 4: a limit, no number; the forecaster's own chance of this, stated with the estimate: 85%; the middle value does not contradict the limit.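

In this assay compound 4 gives > 14000 nM, which is a limit of the assay and not a number. Compound 1 also stands at a limit, so no step can be read between compound 1 and compound 4. The compounds shown leave open whether methyl in place of chloro shifts cytotoxicity at all, and at what concentration any of them reaches the half-maximal effect.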